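This account rests on a few compounds, and the source may have more. Where it says the series, first, only, none or still open, it means among the compounds named here.

Among the measured compounds shown here, in a functional assay on Vero cells (Chlorocebus sabaeus) for inhibition (a higher number here means a weaker inhibitor, a lower number a stronger inhibitor), the series so far gives no number. Compound 1 (`O=c1[nH]c(=O)n([C@@H]2CS[C@@H](CO)O2)cc1Cl`) reads > 100000 nM, which is a limit of the assay and not a number. Compound 2 (`Cc1cn([C@@H]2CS[C@@H](CO)O2)c(=O)[nH]c1=O`) reads > 100000 nM, again a limit. Compound 3 (`O=c1[nH]c(=O)n([C@@H]2CS[C@@H](CO)O2)cc1Br`) reads > 100000 nM, also a limit. Across the series this is the limit of > 100000 nM in this assay, at which 3 of the 3 values shown sit.

Compound 4 (`O=c1[nH]c(=O)n([C@@H]2CS[C@@H](CO)O2)cc1I`) keeps the shared core and carries iodo in place of bromo on an aromatic carbon. For the measured compounds named here, the closest precedent is a step that the two limits leave unreadable from compound 1 to compound 3, with bromo in place of chloro at the same carbon. Also relevant are a step that the two limits leave unreadable from compound 1 to compound 2 and a step that the two limits leave unreadable from compound 2 to compound 3. None of these steps has a readable size, so they offer no support for a shift beyond the scatter in this assay, and no direction is expected.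

The estimated step is a number no higher from compound 3 to compound 4 (the limit leaves the size open). For compound 4 the estimate is 100000 nM, with an expected range of 40000 nM to 250000 nM, and another report as a limit is the likeliest outcome.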

Compound 4, half-maximal inhibitory concentration: > 100000 nM
Compound 4: no number, only a limit (the forecaster's own chance of this, stated with the estimate: 85%); the middle value lies on the limit itself.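

In this assay compound 4 reads as a limit, as do compound 1, compound 2 and compound 3, so no step among these compounds can be read: the limit of > 100000 nM in this assay, at which 4 of the 4 values shown sit.

The compounds shown leave open how strongly any of them inhibits, and whether exchanging the group on the aromatic carbon changes that at all.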